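Series notes: aryl ether variants on the shared core

The compounds below may be only part of what the source reports. "The series", "measured", "known", "first", "only" and "open" are said of these compounds alone.

Three members of the series have numbers in an ADME assay on MT2 cells (Homo sapiens) for cytotoxicity; a higher number here means that more compound is tolerated, a lower number that less compound is tolerated. Compound 1 `COc1ccnc(Nc2ccc(Cl)c(OCC=C(C)C)c2)n1` gives 9000 nM in this assay. Compound 2 `COc1ccnc(Nc2ccc(Cl)c(Oc3ccccc3)c2)n1` gives 38000 nM. Compound 3 `COc1ccnc(Nc2ccc(Cl)c(Oc3ccccc3C)c2)n1` gives 13000 nM, the second highest of the three numbers, close to compound 1 and separated from compound 2 by the step of a 2.9-fold lower number from compound 2 to compound 3 (0.47 log units; beyond the scatter), which lies beyond the scatter. Around compound 1 the steps are a 4.2-fold higher number from compound 1 to compound 2 (0.63 log units; beyond the scatter) and a 1.4-fold higher number from compound 1 to compound 3 (0.16 log units; within the scatter).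

Compound 4 `COc1ccnc(Nc2ccc(Cl)c(Oc3ccc(C)cc3)c2)n1` is not yet measured in this assay. It differs from compound 3 by 4-methylphenyl in place of 2-methylphenyl on an oxygen on an aromatic ring; the two have the same atoms, joined differently, with the methyl moved within the phenyl. Among the compounds with values here, no measured step covers that move directly. The step that bears on it is a 2.9-fold lower number from compound 2 to compound 3 (0.47 log units; beyond the scatter), which shows that adding a methyl to the phenyl of compound 2 lowered the number, and compound 4 also carries a methyl on the phenyl. The number of compound 4 is therefore expected to sit between those of compound 2 and compound 3, nearer compound 3, with the step of a 1.4-fold higher number from compound 3 to compound 4 (0.14 log units; within the scatter) expected to stay within the scatter. For compound 4 the estimate in this assay is 18000 nM, with a range from 7000 nM to 45000 nM.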

Compound 4, half-maximal cytotoxic concentration: > 100000 nM
Compound 4: no number, only a limit; the forecaster's own chance of this, stated with the estimate: 5%; middle value at least 5.5-fold (0.74 log units) away from the limit.
By their numbers in this assay, from the lowest: compounds 1 and 3 (each within the scatter of the next); then compound 2. At a limit, above all of these: compound 4.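

In this assay, compound 4 gives no number, only a limit: the limit of > 100000 nM in this assay, at which 1 of the 4 values shown sits. Moving the methyl on the aryl ether, with the atoms unchanged, gives an at least 7.6-fold higher number from compound 3 to compound 4 (0.88 log units; beyond the scatter), so the earlier picture of a methyl on the phenyl lowering the number holds for 2-methylphenyl but not for 4-methylphenyl. The same added methyl now reads in two directions, with a 2.9-fold lower number from compound 2 to compound 3 (0.47 log units; beyond the scatter) set against an at least 2.6-fold higher number from compound 2 to compound 4 (0.42 log units; beyond the scatter), and the distance from the 3-methylbut-2-en-1-yl ether grows to an at least 11-fold higher number from compound 1 to compound 4 (1.04 log units; beyond the scatter).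

On these data alone, it remains open whether this rise belongs to the methyl of 4-methylphenyl alone or would also appear with another group in the same place on the phenyl, such as a chlorine atom, a methoxy or an amine. As far as these compounds go, the true size of all three steps also remains open, since each one ends at a limit and gives only a lower bound on the change, so the series cannot yet be ranked beyond that limit.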